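This account rests on a few compounds, and the source may have more. Where it says the series, first, only, none or still open, it means among the compounds named here.

Compound 1, `O=C1Nc2ccccc2/C1=C\c1c(Cl)n(Cc2ccccc2)c2ccccc12`, gives 16600 nM in a functional assay on cells (Cancer cell lines, Homo sapiens) for cytotoxicity, with a stated time of 48 h; a lower number here means a stronger inhibitor of growth, a higher number a weaker inhibitor of growth.
Compound 2, `COc1cc2c(/C=C3/C(=O)Nc4ccc(Cl)cc43)c(Cl)n(Cc3cc(OC)c(OC)c(OC)c3)c2cc1C`, gives 2340 nM in this assay.
Compound 3, `COc1cc2c(/C=C3/C(=O)Nc4cccc(Cl)c43)c(Cl)n(Cc3cc(OC)c(OC)c(OC)c3)c2cc1C`, gives 3020 nM in this assay.

Among these three numbers compound 1 stands highest, that is, it is the weakest inhibitor of growth of the three; compounds 2 and 3 both give lower numbers, and their distance from compound 1 lies beyond the scatter. For the measured compounds named here, the one step between compounds that differ in a single place is a 1.3-fold higher number from compound 2 to compound 3 (0.11 log units; within the scatter), which swaps one chlorine-bearing fragment of the shared core for another and leaves the number within the scatter.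

Compound 4, `O=C1Nc2ccccc2/C1=C\c1c(Cl)n(CCCc2ccccc2)c2ccccc12`, differs from compound 1 by phenethyl in place of phenyl on a saturated chain carbon bound to an aromatic nitrogen. Going by the values given here, none of the measured steps bears on this change: compounds 2 and 3 carry the same benzyl group on the aromatic nitrogen as compound 1 and differ from it in several other places at once, so their values say nothing about lengthening that chain. Among the compounds with values here, with no step to lean on, the expectation for this change is a number staying close to that of compound 1, with no shift beyond the scatter, as the estimated step of a 1.3-fold lower number from compound 1 to compound 4 (0.11 log units; within the scatter) expresses. Compound 4 is therefore expected at 13000 nM in this assay. Its estimated range runs from 4000 nM to 40000 nM.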

Compound 4, concentration for 50% growth inhibition: 16600 nM
Estimate against measurement, compound 4: 1.3-fold (0.11 log units) below, and the stated range covers the measured number.
By their numbers in this assay, from the lowest: compounds 2 and 3 (each within the scatter of the next); then compounds 1 and 4 (each within the scatter of the next).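

In this assay, going from benzyl to 3-phenylpropyl on the aromatic nitrogen gives no change at the digits printed from compound 1 to compound 4 (within the scatter), and this is the first step shown at this position, since the only earlier step lay on a chlorine-bearing part of the shared core. For this one pair, then, moving the phenyl ring further out along a longer chain leaves the growth-inhibition number unchanged, so on the core of compound 1 this position accepts the longer chain without any measurable gain or loss. No measurement at hand explains why the number holds steady, and a single pair cannot show whether the chain length matters at all in other settings.

What the compounds shown leave open is whether the position stays this forgiving when the phenyl ring at the end of the chain gives way to a different group, such as an amine or a carboxylic acid. Going by these compounds, it is also open whether 3-phenylpropyl would leave the number just as unchanged on the more heavily substituted core of compound 2 or compound 3.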